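A few compounds are considered here, and "the series" means these few. Any claim that something is new, unique, unknown or untested is made for them only; others in the source may bear on it.

Measured in a functional assay on P388 cells (Mus musculus) for inhibition; a higher number here means a weaker inhibitor, a lower number a stronger inhibitor:
- compound 1 `CC(=O)Oc1ccc(/C=C/c2ccc3ccccc3c2)cc1`: > 5000 nM, a limit
- compound 2 `Cc1ccc(/C=C/c2ccc3ccccc3c2)cc1`: > 5000 nM, a limit

Compound 2 therefore stands at a limit and has no exact number. Compound 3 `Cc1ccc(/C=C\c2ccc3ccccc3c2)cc1` is its counterpart: the two compounds have the same atoms and bonds and differ only in configuration as drawn: 1 of 1 stereo elements differ; a double bond is drawn E in compound 2 and Z in compound 3.

Among the measured compounds shown here, the only measured step is a step that the two limits leave unreadable from compound 1 to compound 2. The evidence on it is the limit of > 5000 nM in this assay, at which 2 of the 2 values shown sit. It offers no size to carry over to this change, so no clear step in either direction can be forecast in this assay, and compound 3 may well report only a limit too.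

Compound 3 is expected near 6000 nM, with an estimated range of 1500 nM to 25000 nM. The expected step is a step that the limit leaves unreadable from compound 2 to compound 3.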

Compound 3, half-maximal inhibitory concentration: > 5000 nM
Compound 3: a limit, no number; the forecaster's own chance of this, stated with the estimate: 65%; the middle value is on the limit's open side.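

Compound 2 and compound 3 both report only a limit in this assay, so no step can be read between them. On these data alone, the true strength of each compound, and whether the E or Z double bond matters for inhibition, stay open.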